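The source may report more compounds than this note shows. Statements on the series, on what has been measured and on what is new or still open speak of the compounds shown alone.

Of the compounds shown here, three built on a shared core have been tested in a functional assay on A-375 cells (Homo sapiens) for inhibition; on this read-out lower numbers stand for stronger inhibition and higher numbers for weaker inhibition. Compound 1 `N#CC1CN1C(=O)NCc1ccccc1` gives 11000 nM in this assay . Compound 2 `CCCCNC(=O)N1CC1C#N` gives 15000 nM in this assay . Compound 3 `N#CC1CN1C(=O)NC1CCCCC1` gives 35000 nM in this assay . Among these three numbers compound 2 stands second highest: its value and that of compound 1 lie within the usual scatter of each other, so nothing separates them, whereas compound 3 gives a higher number, beyond the scatter, and so inhibits less strongly than either.

Compound 4 `N#CC1CN1C(N)=O` differs from compound 2 in one place, (hydrogen in place of butyl on an amide-type nitrogen). Going by the values given here, no pair among the measured compounds shows a step of this kind, so its size must be judged from the weak inhibition seen throughout. Since every measured compound gives a high number, the bare urea of compound 4 is expected to give a number in the same region or higher. Compound 4 is therefore expected to give about 30000 nM in this assay , within a range from 10000 nM to 100000 nM. The step of a 2.0-fold higher number from compound 2 to compound 4 (0.30 log units; within the scatter) is estimated to be modest and toward weaker inhibition.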

Compound 4, half-maximal inhibitory concentration: > 90000 nM
Compound 4 gave a limit, no number; the forecaster's own chance of this, stated with the estimate: 30%; at least 3.0-fold (0.47 log units) between middle value and limit.
By their numbers in this assay, from the lowest: compounds 1 and 2 (each within the scatter of the next); then compound 3. At a limit, above all of these: compound 4.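

In this assay compound 4 gives > 90000 nM, which is a limit of the assay and not a number. Hydrogen in place of butyl on an amide-type nitrogen gives an at least 6.0-fold higher number from compound 2 to compound 4 (0.77 log units; beyond the scatter), the first single change in the series whose effect can be read, and it shows that inhibition at this position depends on the substituent being present, which the earlier compounds, with no pair differing in one place, could not show. The step is known from one side only, with no upper end: the limit of > 90000 nM in this assay, at which 1 of the 4 values shown sits.

From the compounds shown here alone, what remains open is how inhibition falls away along the chain, since a methyl or an ethyl on this nitrogen would lie between hydrogen and butyl. Also open, going by these compounds, is whether a longer chain such as hexyl, or a chain ending in an amine or a carboxylic acid, would keep the inhibition seen with butyl.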